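Swapping a Dichlorophenoxy for a Fluorophenylthio Group

The compounds below may be only part of what the source reports. "The series", "measured", "known", "first", "only" and "open" are said of these compounds alone.

compound 1 `Nc1cc(N)c2nc(-c3ccccc3)c(Oc3ccc(Cl)c(Cl)c3)nc2c1` — 87100 nM
compound 2 `COc1ccc(CNc2nc3cc(N)cc(N)c3nc2-c2ccccc2)cc1` — 30200 nM

In a functional assay on UACC-257 cells (Homo sapiens) for inhibition, read by sulforhodamine B assay, with a stated time of 48 h (on this read-out lower numbers stand for stronger inhibition of growth and higher numbers for weaker inhibition of growth), compound 1 gives 87100 nM, the highest of the two numbers, while compound 2 gives 30200 nM, a gap beyond the scatter. Compound 3 `Nc1cc(N)c2nc(-c3ccccc3)c(Sc3ccc(F)cc3)nc2c1` has not been measured. It differs from compound 1 in one place: (4-fluorophenyl)sulfanyl in place of 3,4-dichlorophenoxy on an aromatic carbon. Going by the values given here, no measured pair shows this change, so its effect is uncertain. A modest step towards a lower number is expected, one that may not exceed the scatter, as given by a 1.5-fold lower number from compound 1 to compound 3 (0.16 log units; within the scatter). Compound 3 is estimated at 60000 nM, within 15000 nM to 200000 nM.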

Compound 3, concentration for total growth inhibition: 31600 nM
Beside the measured number, compound 3's estimate is 1.9-fold (0.28 log units) above it, within the range that was stated.
By their numbers in this assay, from the lowest: compounds 2 and 3 (each within the scatter of the next); then compound 1.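

With a 2.8-fold lower number from compound 1 to compound 3 (0.44 log units; beyond the scatter) in this assay, the change from 3,4-dichlorophenoxy to (4-fluorophenyl)sulfanyl shows that the number responds to the group at this position on the shared core. It is the only one-place change shown here, and its size goes beyond the scatter while remaining modest. No accompanying measurement accounts for this step. The compounds shown do not separate the sulfur link from the ring substituents, which change together. They also leave open how an amine or a carboxylic acid would read at this position.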